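Methoxy Added to the Methyl of Compound 2

A few compounds are considered here, and "the series" means these few. Any claim that something is new, unique, unknown or untested is made for them only; others in the source may bear on it.

Compound 1 `COCC1=C(C(=O)NCCCN2CCC(c3ccc(F)cc3C#N)CC2)[C@@H](c2ccc(F)c(F)c2)NC(=O)N1` is measured in an in vitro assay on HEK293 cells with Alpha-1D adrenergic receptor (Homo sapiens) as the target (on this read-out lower numbers stand for stronger inhibition and higher numbers for weaker inhibition), and gives 260 nM. Compound 2 `CC1=C(C(=O)NCCCN2CCC(c3ccccn3)CC2)[C@@H](c2ccc(F)c(F)c2)NC(=O)N1` differs from compound 1 in two places, not one. In this assay compound 2 reaches only a limit of the assay, > 5000 nM. Compound 2 thus stands at the limit, where one of the two values shown sits (the limit of > 5000 nM in this assay, at which 1 of the 2 values shown sits). Among the measured compounds shown here, no step between measured compounds that differ in a single place is available, so the two values show only that compound 1 gives a number and compound 2 does not.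

Compound 3 `COCC1=C(C(=O)NCCCN2CCC(c3ccccn3)CC2)[C@@H](c2ccc(F)c(F)c2)NC(=O)N1` differs from compound 2 by methoxy in place of hydrogen on a saturated chain carbon bound to a double-bonded ring carbon. The second difference between compound 1 and compound 2 is not isolated, so the weight of this change alone cannot be read from the data. The expected step from compound 2 to compound 3 is an at least 1.6-fold lower number from compound 2 to compound 3 (0.22 log units; that floor lies within the scatter), toward stronger inhibition, though uncertain. For compound 3 a value of 3000 nM is estimated, within 800 nM to 10000 nM.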

Compound 3, inhibition constant: 495 nM
For compound 3 the middle estimate is 6.1-fold (0.78 log units) above the measured one; the whole stated range lies above it.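

In this assay, methoxy in place of hydrogen on a saturated chain carbon bound to a double-bonded ring carbon now stands as a single change, and it gives an at least 10-fold lower number from compound 2 to compound 3 (1.00 log units; beyond the scatter). Compound 2 holds a limit of the assay and not a number, so this step is only a floor: the limit of > 5000 nM in this assay, at which 1 of the 3 values shown sits. The other single change, pyridin-2-yl in place of 2-cyano-4-fluorophenyl on a saturated ring carbon, gives a 1.9-fold higher number from compound 1 to compound 3 (0.28 log units; within the scatter), so with methoxymethyl present the compounds shown do not separate these two groups.

The compounds shown leave open whether an ethyl or a hydroxymethyl in place of methoxymethyl would give a similar number. They also leave open what the change from methyl to methoxymethyl does with 2-cyano-4-fluorophenyl in place of pyridin-2-yl.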